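The compounds below may be only part of what the source reports. "The series", "measured", "known", "first", "only" and "open" are said of these compounds alone.

Measured in a functional assay on HeLa cells (Homo sapiens) for inhibition, read by MTT assay, with a stated time of 72 h; on this read-out lower numbers stand for stronger inhibition and higher numbers for weaker inhibition:
- compound 1 `CN(C(=O)NC(=O)c1ccccc1F)c1nc(C(F)(F)F)c(C(=O)N/N=C/c2ccc(C(F)(F)F)cc2)s1` gives 3.97 ug/mL
- compound 2 `CN(C(=O)NC(=O)c1ccccc1F)c1nc(C(F)(F)F)c(C(=O)N/N=C/c2ccccc2C(F)(F)F)s1` gives 10.1 ug/mL
- compound 3 `CN(C(=O)NC(=O)c1cccc(C(F)(F)F)c1)c1nc(C(F)(F)F)c(C(=O)N/N=C/c2ccccc2C(F)(F)F)s1` gives 7.37 ug/mL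

Compound 1 has the lowest number of the three; compound 3 sits within the scatter of it, while compound 2 lies beyond it, the latter gap being a 2.5-fold higher number from compound 1 to compound 2 (0.41 log units; beyond the scatter). Compound 4 `CN(C(=O)NC(=O)c1ccc(F)c(F)c1)c1nc(C(F)(F)F)c(C(=O)N/N=C/c2ccc(C(F)(F)F)cc2)s1` keeps the aryl on the carbon with a double bond to nitrogen of compound 1 and changes only the group on the carbonyl carbon: 3,4-difluorophenyl in place of 2-fluorophenyl on a carbonyl carbon. Among the measured compounds shown here, the one measured step that also swaps that group, a 1.4-fold lower number from compound 2 to compound 3 (0.14 log units; within the scatter), stayed within the scatter. A shift no larger than that is therefore expected for compound 4, a 1.1-fold higher number from compound 1 to compound 4 (0.05 log units; within the scatter). Compound 4 is estimated at 4.5 ug/mL, with a range from 2.2 ug/mL to 9.5 ug/mL.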

Compound 4, half-maximal inhibitory concentration: 5.1 ug/mL
Estimate against measurement, compound 4: 1.1-fold (0.05 log units) below, and the stated range covers the measured number.
By their numbers in this assay, from the lowest: compounds 1, 4, 3 and 2 (each within the scatter of the next, the first and the last beyond it).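

In this assay, 3,4-difluorophenyl in place of 2-fluorophenyl on the carbonyl carbon gives a 1.3-fold higher number from compound 1 to compound 4 (0.11 log units; within the scatter). Alongside a 1.4-fold lower number from compound 2 to compound 3 (0.14 log units; within the scatter), this is a second swap of the aryl on that carbonyl carbon to stay within the scatter, now with 4-(trifluoromethyl)phenyl rather than 2-(trifluoromethyl)phenyl on the carbon with a double bond to nitrogen. No supporting evidence accompanies this result to explain it. The compounds shown leave open whether a group other than a fluorinated or trifluoromethyl-bearing phenyl on that carbonyl carbon, such as a longer alkyl chain or a methoxyphenyl, would stay within that range.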